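The source may hold more compounds than are shown below. What is called first, only, known or untested is meant among the compounds shown, and "the series" means these compounds.

In a functional assay (trachea) with Cavia porcellus as the target (on this read-out lower numbers stand for an effect already at smaller amounts and higher numbers for an effect only at larger amounts of compound), compound 2 `CCCn1c(=O)n(CCC(=O)O)c(=O)c2[nH]cnc21` gives 21200 nM, the highest of the two numbers recorded so far. Its nearest neighbour is compound 1 `CCCn1c(=O)n(CC)c(=O)c2[nH]cnc21`, which in this assay gives 1300 nM. The two differ in one place, and the step between them, a 16-fold higher number from compound 1 to compound 2 (1.21 log units; beyond the scatter), came with carboxy in place of hydrogen on a saturated chain carbon, two bonds along the chain from an aromatic nitrogen.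

Compound 3 `CCCn1c(=O)n(CCC#N)c(=O)c2[nH]cnc21` has not yet been measured in this assay. It differs from compound 2 in one place: cyano in place of carboxy on a saturated chain carbon, two bonds along the chain from an aromatic nitrogen. Going by the values given here, the only measured step that bears on this change is a 16-fold higher number from compound 1 to compound 2 (1.21 log units; beyond the scatter), which shows how strongly the number rose when carboxy entered at this position. In compound 3 the carboxy leaves and a cyano enters, so a partial return toward the number of compound 1, 1300 nM, is expected rather than a full one. For compound 3 the expected step is a 4.2-fold lower number from compound 2 to compound 3 (0.63 log units; beyond the scatter). For compound 3 the estimate in this assay is 5000 nM, with a range from 1500 nM to 16000 nM.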

Compound 3, half-maximal effective concentration: 1700 nM
For compound 3 the middle estimate is 2.9-fold (0.47 log units) above the measured one; measured number inside the range.
By their numbers in this assay, from the lowest: compounds 1 and 3 (each within the scatter of the next); then compound 2.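

In this assay, the change from carboxy to cyano on this chain carbon gives a 12-fold lower number from compound 2 to compound 3 (1.10 log units; beyond the scatter) and so reverses most of the rise that carboxy had brought. The comparison with the parent chain gives a 1.3-fold higher number from compound 1 to compound 3 (0.12 log units; within the scatter) and shows that this place accepts a cyano group in place of hydrogen with no change beyond the usual scatter. Among these three compounds, the high number therefore goes with carboxy in particular, not with any group placed at this carbon, and no measurement is available that accounts for the contrast between carboxy and cyano.

As far as these compounds go, it remains open whether other groups at this carbon, such as an amine, a hydroxy group, a primary amide or a methyl ester, would stay with compound 1 and compound 3 or move toward compound 2. From the compounds shown here alone, it is also open how a longer chain bearing either carboxy or cyano would read in this assay, and whether the same contrast holds when the propyl group on the other ring nitrogen is replaced.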